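From cyclopropyl to dimethylamino on a sulfonyl sulfur

This account rests on a few compounds, and the source may have more. Where it says the series, first, only, none or still open, it means among the compounds named here.

Measured in an ADME assay on the whole organism (liver, Rattus norvegicus, strain Sprague-Dawley) for pharmacokinetics, read by LC-MS, with a stated time of 24 h, at a dose of 30 mg/kg by the oral route; a lower number here means less compound in the circulation, a higher number more compound in the circulation at the dose given
Compound 1 `CC(C)(C)OC(=O)N[C@H]1CCCCC/C=C\[C@@H]2C[C@@]2(C(=O)NS(=O)(=O)C2CC2)NC(=O)[C@@H]2C[C@@H](OC(=O)N3CCc4ccccc4C3)CN2C1=O` gives 277000 ng.h/mL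
Compound 2 `CC(C)(C)OC(=O)N[C@H]1CCCCC/C=C\[C@@H]2C[C@@]2(C(=O)NS(=O)(=O)C2CC2)NC(=O)[C@@H]2C[C@@H](OC(=O)N3Cc4ccccc4C3)CN2C1=O` gives 40300 ng.h/mL

Compound 2 holds the lower of the two numbers. Compound 3 `CN(C)S(=O)(=O)NC(=O)[C@@]12C[C@H]1/C=C\CCCCC[C@H](NC(=O)OC(C)(C)C)C(=O)N1C[C@H](OC(=O)N3Cc4ccccc4C3)C[C@H]1C(=O)N2` differs from it by dimethylamino in place of cyclopropyl on a sulfonyl sulfur. Going by the values given here, the only measured step of a 6.9-fold lower number from compound 1 to compound 2 (0.84 log units; beyond the scatter) lies on a carbonyl carbon and not on the sulfonyl sulfur, so it shows how large one change can be but gives no direction here. For compound 3, no change beyond the scatter is therefore expected in this assay at this point. The estimated step is a 1.2-fold lower number from compound 2 to compound 3 (0.06 log units; within the scatter) and it remains uncertain. For compound 3 the estimate is 35000 ng.h/mL with an expected range of 9000 ng.h/mL to 130000 ng.h/mL until it is measured.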

Compound 3, area under the concentration-time curve in the liver assay: 136000 ng.h/mL
Estimate against measurement, compound 3: 3.9-fold (0.59 log units) below; measured number above the stated range.
By their numbers in the liver assay, from the lowest: compound 2; then compound 3; then compound 1.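

In the liver assay compound 2 gives 40300 ng.h/mL and compound 3 gives 136000 ng.h/mL so the sulfonyl sulfur proves a position that matters, with dimethylamino in place of cyclopropyl giving a 3.4-fold higher number from compound 2 to compound 3 (0.53 log units; beyond the scatter). In a physicochemical assay for lipophilicity (a higher number here means a more lipophilic compound, a lower number a more polar compound), compound 2 gives 2.4 and compound 3 gives 2.5 and the same change gives a number 0.10 log units higher from compound 2 to compound 3 (within the scatter), so that read-out does not separate the two compounds. Nothing measured here accounts for the step in the circulation. As far as these compounds go, whether the change holds on the core of compound 1 remains open. So does how a cyclic amine such as pyrrolidine or morpholine on the sulfonyl sulfur would compare with dimethylamino.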